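Sulfamoyl in Place of Fluoro: From Compound 2 to Compound 4

The source may hold more compounds than are shown below. What is called first, only, known or untested is meant among the compounds shown, and "the series" means these compounds.

Compound 1, `CCCCCCCCCCCCCCOc1cccc(N2C(N)=NC(N)=NC2(C)C)c1`, gives 6.49.
Compound 2, `CC1(C)N=C(N)N=C(N)N1c1cccc(F)c1`, gives 5.24.
Compound 3, `COc1cccc(OCc2cccc(N3C(N)=NC(N)=NC3(C)C)c2)c1`, gives 5.36.

In a functional assay on L5178Y cells (Mus musculus) (a higher number here means a more potent compound, by a factor of ten per unit of this negative logarithm, a lower number a less potent compound), compound 2 has the lowest of the three numbers; compound 3 sits within the usual scatter of it, while compound 1 stands beyond the scatter, higher. Compound 4, `CC1(C)N=C(N)N=C(N)N1c1cccc(S(N)(=O)=O)c1`, differs from compound 2 in a single place: sulfamoyl in place of fluoro on an aromatic carbon. Within the data shown here, no measured pair in this set shows the same change, so the numbers give no direct guide to its size. The expected step is a number 0.04 log units lower from compound 2 to compound 4 (within the scatter), with no direction that clearly exceeds the scatter. Compound 4 is therefore estimated at 5.2, in a range from 4.6 to 5.8.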

Compound 4, logarithm of the reciprocal of the active concentration, log(1/C): 3.13
The estimate for compound 4 lay 2.07 log units above the measured number, outside the stated range (below it).
By their numbers in this assay, from the lowest: compound 4; then compounds 2 and 3 (each within the scatter of the next); then compound 1.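

Sulfamoyl in place of fluoro on an aromatic carbon brings a number 2.11 log units lower from compound 2 to compound 4 (beyond the scatter) in this assay and so shows that this place, meta to a large group, does not take every substituent alike. Among these compounds, the earlier compounds offered no single change of this kind, so this is the first direct reading of how much the group here can matter. Nothing available explains the drop. The compounds shown leave open whether the loss is specific to sulfamoyl, or whether a methylsulfonyl group, a carboxylic acid or an amine in the same place would read the same way.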